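Adding a Methoxy Group to Compound 1

The compounds below may be only part of what the source reports. "The series", "measured", "known", "first", "only" and "open" are said of these compounds alone.

Measured compounds:
- compound 1 `COc1ccc(C(=O)/C=C/c2cc(-c3cc(OC)c(OC)c(OC)c3)n[nH]2)cc1OC` gives 2760 nM in a functional assay on LOX IMVI cells (Homo sapiens) for inhibition, read by sulforhodamine B assay, with a stated time of 48 h; on this read-out lower numbers stand for stronger inhibition of growth and higher numbers for weaker inhibition of growth
- compound 2 `COc1cc(-c2cc(/C=C/C(=O)c3ccc(F)c(F)c3)[nH]n2)cc(OC)c1OC` gives 12200 nM in this assay

Compound 1 holds the lower of the two numbers in this assay. Its nearest neighbour is compound 2, reached by a 4.4-fold higher number from compound 1 to compound 2 (0.65 log units; beyond the scatter), with 3,4-difluorophenyl in place of 3,4-dimethoxyphenyl on the carbonyl carbon.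

Compound 3 `COc1cc(C(=O)/C=C/c2cc(-c3cc(OC)c(OC)c(OC)c3)n[nH]2)cc(OC)c1OC` has not been measured. It differs from compound 1 by methoxy in place of hydrogen on an aromatic carbon, on the six-membered aromatic ring of carbon only, ortho to a methoxy group and meta to a methoxy group and to a large group.

Among the compounds with values here, the single measured step, from compound 1 to compound 2, changes the same ring that the new methoxy enters, but it swaps the whole substitution pattern rather than adding one group, so it bears on this change only loosely. It shows that the ring attached to the carbonyl matters beyond the scatter. Within the data shown here, no step isolates an added methoxy, so the expected step from compound 1 to compound 3 is a 1.4-fold lower number from compound 1 to compound 3 (0.14 log units; within the scatter), judged likely to stay within or just beyond the scatter. Compound 3 is therefore estimated at 2000 nM, within 700 nM to 6000 nM.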

Compound 3, concentration for total growth inhibition: 2910 nM
Compound 3: middle estimate off by 1.5-fold (0.16 log units), on the low side; the range from low to high includes it.
By their numbers in this assay, from the lowest: compounds 1 and 3 (each within the scatter of the next); then compound 2.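

In this assay, within the data shown here, the added methoxy gives a 1.1-fold higher number from compound 1 to compound 3 (0.02 log units; within the scatter) and so lies within the scatter, which makes this the first step to isolate a single added group on the ring attached to the carbonyl. At this place, ortho to a methoxy group and meta to a large group, methoxy in place of hydrogen therefore produces no readable change in the concentration for total growth inhibition. The earlier step of a 4.4-fold higher number from compound 1 to compound 2 (0.65 log units; beyond the scatter) had shown only that replacing the whole substitution pattern of this ring can move the number beyond the scatter, so the sensitivity seen there does not extend to this single added methoxy.

On these data alone, whether a different group at this same place, such as an amine, a carboxylic acid or a longer chain like butoxy, would also leave the number within the scatter remains open, as does whether the added methoxy would behave the same way with other groups on the rest of this ring. Nothing measured here speaks to the reason for the flat result at this position.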